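Swapping Methyl for Phenyl in a Cell Toxicity Test

The compounds below may be only part of what the source reports. "The series", "measured", "known", "first", "only" and "open" are said of these compounds alone.

Three related compounds have been measured in an ADME assay on HeLa cells (Homo sapiens) for cytotoxicity, read by MTT assay, with a stated time of 2 days; on this read-out lower numbers stand for higher toxicity in this test and higher numbers for lower toxicity in this test. In this assay, compound 1 `CNC(=O)c1cc(Oc2ccc3cc(C(=O)OC)sc3c2)ccn1` gives 68300 nM. Compound 2 `CCOC(=O)c1sc2cc(Oc3ccnc(C(=O)NC)c3)ccc2c1C#N` returns only a limit of the test, > 100000 nM. Compound 3 `CNC(=O)c1cc(Oc2ccc3ccc(C(=O)OC)cc3c2)ccn1` gives 33800 nM, the lower of the two actual numbers, and its gap to compound 1 lies just beyond the usual scatter.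

The next compound is compound 4 `CNC(=O)c1cc(Oc2ccc3ccc(C(=O)Oc4ccccc4)cc3c2)ccn1`, which differs from compound 3 in one place: phenyl in place of methyl on an oxygen next to a carbonyl group. Among the measured compounds shown here, no measured pair shows this kind of swap, so the expectation is a loose one. The likeliest outcome is no step beyond the scatter, with a slight lean toward a lower number, which would mean somewhat higher toxicity. The expected change is a 1.3-fold lower number from compound 3 to compound 4 (0.11 log units; within the scatter). Compound 4 is estimated at 26000 nM, with an expected range of 8000 nM to 85000 nM.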

Compound 4, half-maximal cytotoxic concentration: > 100000 nM
Compound 4 was reported as a limit (the forecaster's own chance of this, stated with the estimate: 15%); middle value at least 3.8-fold (0.58 log units) from the limit.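

In this assay, the group on an oxygen next to a carbonyl group turns out to matter: phenyl in place of methyl gives an at least 2.9-fold higher number from compound 3 to compound 4 (0.47 log units; beyond the scatter), so a higher number here means lower toxicity in this test. Compound 4 gives > 100000 nM, which is a limit of the test and not a number. The step therefore marks only the smallest size the change can have, and its full size cannot be read: the limit of > 100000 nM in this assay, at which 2 of the 4 values shown sit.

From the compounds shown here alone, what a carboxylic acid or a longer chain would give at this same place remains open, as does how the number moves for groups sized between methyl and phenyl. Going by these compounds, it is also open whether the same swap on the core of compound 1 would shift the number in the same direction.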